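The compounds below may be only part of what the source reports. "The series", "measured", "known", "first", "only" and "open" are said of these compounds alone.

Compound 1 `OC[C@H]1O[C@@H](n2cnc3c(NCc4ccc(Cl)cc4)ncnc32)[C@H](O)[C@@H]1O` carries a 4-chlorobenzyl group on the amine of the shared core. In a functional assay on B16 cells (Mus musculus) for antiproliferative activity, with a stated time of 72 h (on this read-out higher numbers stand for weaker inhibition and lower numbers for stronger inhibition), compound 1 reaches only the limit of the assay, > 166000 nM. Its closest neighbour, compound 2 `OC[C@H]1O[C@@H](n2cnc3c(NCc4ccc(Br)cc4)ncnc32)[C@H](O)[C@@H]1O`, differs by bromo in place of chloro on an aromatic carbon. In this assay compound 2 also stops at the limit, > 166000 nM. The step that the two limits leave unreadable from compound 1 to compound 2 therefore cannot be read, since the limit of > 166000 nM in this assay, at which 2 of the 3 values shown sit, covers both ends of it. A third member, compound 3 `COc1cccc(CNc2ncnc3c2ncn3[C@@H]2O[C@H](CO)[C@@H](O)[C@H]2O)c1OC`, brings no result: for compound 3 the entry in this assay reads "not determined" (no result reported).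

Compound 4 `Cc1cccc(CNc2ncnc3c2ncn3[C@@H]2O[C@H](CO)[C@@H](O)[C@H]2O)c1O` is the next member. The change from compound 1 is 2-hydroxy-3-methylphenyl in place of 4-chlorophenyl on a saturated chain carbon bound to a nitrogen on an aromatic ring. For the measured compounds named here, no measured step bears on this change: the single step between compound 1 and compound 2 is unreadable, and compound 3 gives no number at all. Going by the values given here, compound 1 itself stands at the limit, and nothing among the measured compounds indicates a move away from it. For compound 4 the expected step is therefore a number no higher from compound 1 to compound 4 (the limit leaves the size open), which is no more than the scatter. Compound 4 is accordingly estimated at 166000 nM in this assay, with a range from 50000 nM to 500000 nM, and most probably only a limit will again be reported.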

Compound 4, half-maximal inhibitory concentration: > 166000 nM
Compound 4 gave a limit, no number (the forecaster's own chance of this, stated with the estimate: 85%); the middle value sits exactly at the limit.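

In this assay compound 4 again gives only a limit, > 166000 nM. Its steps from compound 1 and from compound 2 therefore cannot be read, as all three stop at the same limit: the limit of > 166000 nM in this assay, at which 3 of the 4 values shown sit. The compounds shown leave open whether any group in this place on the shared core gives a real number in this assay.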